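Replacing a Naphthyl Arm with a Methoxyphenyl Group

A few compounds are considered here, and "the series" means these few. Any claim that something is new, unique, unknown or untested is made for them only; others in the source may bear on it.

Of the compounds shown here, two of a shared core have been tested in a functional assay on MCF7 cells (Homo sapiens) for inhibition, read by MTT assay, with a stated time of 24 h; on this read-out lower numbers stand for stronger inhibition and higher numbers for weaker inhibition. Compound 1 `CCOC(=O)C1=Cc2ccccc2OC1(OCc1cc(-c2ccc(C)cc2)no1)C(F)(F)F` reaches only the edge of the assay, with > 150000 nM recorded as a limit rather than a number. For the measured compounds named here, compound 2 `CCOC(=O)C1=Cc2ccccc2OC1(OCc1cc(-c2ccc3ccccc3c2)no1)C(F)(F)F` gives 65400 nM in this assay, the only actual number among the values shown. Going by the values given here, the single measured step, an at least 2.2-fold lower number from compound 1 to compound 2 (0.36 log units; beyond the scatter), is the whole of the evidence, and it starts from the limit of > 150000 nM in this assay, at which 1 of the 2 values shown sits. Compound 3 `CCOC(=O)C1=Cc2ccccc2OC1(OCc1cc(-c2ccc(OC)cc2)no1)C(F)(F)F` differs from compound 2 by 4-methoxyphenyl in place of naphthalen-2-yl on an aromatic carbon. This change runs counter to the measured step: the entering group, like the 4-methylphenyl of compound 1, is a single six-membered ring where compound 2 carries two aromatic rings. The expected step is therefore a rise in the number by about a 2.0-fold higher number from compound 2 to compound 3 (0.30 log units; within the scatter), perhaps back toward the limit. The estimate for compound 3 is 130000 nM, within the range 50000 nM to 300000 nM.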

Compound 3, half-maximal inhibitory concentration: > 150000 nM
Compound 3: a limit, no number (the forecaster's own chance of this, stated with the estimate: 45%); middle value at least 1.1-fold (0.06 log units) away from the limit.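

With 4-methoxyphenyl on this aromatic carbon of the five-membered ring, this assay shows an at least 2.2-fold higher number from compound 2 to compound 3 (0.36 log units; beyond the scatter) and so the earlier step no longer rests on a single comparison. Compound 3 ends at a limit and not a number, as compound 1 does, and the step between these two single-ring compounds cannot be read. Of the three compounds, only compound 2, with naphthalen-2-yl and its two aromatic rings, gives an actual number, and neither of the others goes against this: the limit of > 150000 nM in this assay, at which 2 of the 3 values shown sit.

On these data alone, it remains open whether the second aromatic ring itself is what matters, or whether a single phenyl ring bearing an amine or a carboxylic acid in place of methoxy could also give a number. As far as these compounds go, how a pyridine ring or a longer chain would read at this place also remains open.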